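Swapping chloro for methoxy on the benzyl arm

The source may report more compounds than this note shows. Statements on the series, on what has been measured and on what is new or still open speak of the compounds shown alone.

Two compounds of a shared core have been run in a functional assay on MCF7 cells (Homo sapiens) for antiproliferative activity, read by sulforhodamine B assay, with a stated time of 48 h; a higher number here means a weaker inhibitor of growth, a lower number a stronger inhibitor of growth. Compound 1 `COc1ccc(Cn2cc(CNC(=O)c3cn(-c4ccccc4)nc3-c3ccccc3)nn2)cc1` carries a methoxybenzyl on its triazole and an unsubstituted phenyl on the other side; in this assay compound 1 reaches only the limit > 100000 nM, so no number is known for it. Among the compounds with values here, compound 2 `O=C(NCc1cn(Cc2ccc(Cl)cc2)nn1)c1cn(-c2ccccc2)nc1-c1ccc(F)cc1` instead carries a chlorobenzyl together with a fluorophenyl, and in this assay compound 2 gives 130 nM, the only real number in the set. The value of compound 1 is a limit of the assay: the limit of > 100000 nM in this assay, at which 1 of the 2 values shown sits. Within the data shown here, no single-change step connects these two, since they differ in two places at once.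

Compound 3 `COc1ccc(Cn2cc(CNC(=O)c3cn(-c4ccccc4)nc3-c3ccc(F)cc3)nn2)cc1` is the missing link: it keeps the fluorophenyl of compound 2 and takes the methoxybenzyl of compound 1. The change from compound 2 is methoxy in place of chloro on an aromatic carbon. The weak showing of compound 1, which also carries the methoxybenzyl, suggests this exchange costs potency. The step from compound 2 to compound 3 is therefore expected to be a clear loss, estimated at a 23-fold higher number from compound 2 to compound 3 (1.36 log units; beyond the scatter), well beyond the scatter. Compound 3 is thus expected to give about 3000 nM in this assay, somewhere between 300 nM and 60000 nM.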

Compound 3, concentration for 50% growth inhibition: 650 nM
For compound 3 the middle estimate is 4.6-fold (0.66 log units) above the measured one, within the range that was stated.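

Methoxy in place of chloro on the benzyl arm, para to a large group, turns out to be tolerated at a price in this assay: the change gives a 5.0-fold higher number from compound 2 to compound 3 (0.70 log units; beyond the scatter), a modest loss that leaves growth inhibition clearly measurable. The earlier compounds shown here could not separate the methoxybenzyl from the missing fluoro, but with the methoxybenzyl held fixed, fluoro in place of hydrogen on an aromatic carbon gives an at least 150-fold lower number from compound 1 to compound 3 (2.18 log units; beyond the scatter), a large step and the greater of the two. The methoxybenzyl alone therefore does not account for the weak showing of compound 1, whose value is a limit of the assay and not a number: the limit of > 100000 nM in this assay, at which 1 of the 3 values shown sits.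

As far as these compounds go, what remains open is whether the fluoro step would be as large with the 4-chlorobenzyl arm in place, since only the methoxybenzyl series shows it. Also open, from the compounds shown here alone, is how a methyl, a hydroxyl or an amine would fare on the same benzyl carbon, and whether chloro or a methyl could stand in for the fluoro on the phenyl.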